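Two Halogen Swaps on One Shared Core, All at the Limit

The compounds below may be only part of what the source reports. "The series", "measured", "known", "first", "only" and "open" are said of these compounds alone.

Three close relatives share one large fused core. Compound 1 `CO[C@@H]1[C@H](N(C)c2ncc(-c3c[nH]c4ccc(F)cc34)s2)C[C@H]2O[C@]1(C)n1c3ccccc3c3c4c(c5c6ccccc6n2c5c31)C(=O)NC4` is the reference point. In a functional assay on K562 cells (Homo sapiens) for antiproliferative activity, read by CellTiter-Glo, with a stated time of 72 h (a higher number here means a weaker inhibitor, a lower number a stronger inhibitor), compound 1 gives only a limit of the assay, > 10000 nM. Compound 2 `CO[C@@H]1[C@H](N(C)c2ncc(-c3c[nH]c4ccc(Cl)cc34)s2)C[C@H]2O[C@]1(C)n1c3ccccc3c3c4c(c5c6ccccc6n2c5c31)C(=O)NC4` differs from compound 1 by chloro in place of fluoro on an aromatic carbon. In this assay compound 2 also reaches only the limit, > 10000 nM. Compound 3 `CO[C@@H]1[C@H](N(C)c2ncc(-c3c[nH]c4ccc(F)cc34)s2)C[C@H]2O[C@]1(C)n1c3ccccc3c3c4c(c5c6cc(Br)ccc6n2c5c31)C(=O)NC4` carries a different core. In this assay compound 3 again gives only the limit, > 10000 nM. The steps a step that the two limits leave unreadable from compound 1 to compound 2 and a step that the two limits leave unreadable from compound 1 to compound 3 cannot be sized because of the limit of > 10000 nM in this assay, at which 3 of the 3 values shown sit.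

Compound 4 `CO[C@@H]1[C@H](N(C)c2ncc(-c3c[nH]c4ccc(Cl)cc34)s2)C[C@H]2O[C@]1(C)n1c3ccccc3c3c4c(c5c6cc(Br)ccc6n2c5c31)C(=O)NC4` is not yet measured. It differs from compound 3 by chloro in place of fluoro on an aromatic carbon, the same change as from compound 1 to compound 2, at a place described in identical words; the two cores differ by bromo in place of hydrogen on an aromatic carbon. Set beside a step that the two limits leave unreadable from compound 1 to compound 2, the expected step that the limit leaves unreadable from compound 3 to compound 4 rests on that unreadable earlier step. Compound 4 is therefore expected in this assay to lie near 15000 nM, most likely again only a limit.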

Compound 4, half-maximal inhibitory concentration: > 10000 nM
Compound 4 was reported as a limit; the forecaster's own chance of this, stated with the estimate: 85%; the middle value lies beyond the limit too.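

No step from compound 2 or compound 3 to compound 4 can be read, because all of these results stop at the same assay limit: the limit of > 10000 nM in this assay, at which 4 of the 4 values shown sit.

The compounds shown leave open whether either halogen swap changes activity in this assay at all: none of them gives an actual number.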